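The source may hold more compounds than are shown below. What is called first, only, known or untested is meant among the compounds shown, and "the series" means these compounds.

Measured compounds in an ADME assay on HepG2 cells (Homo sapiens) for cytotoxicity, read by CellTiter-Glo and resazurin assay, with a stated time of 72 h; on this read-out higher numbers stand for an effect only at larger amounts of compound and lower numbers for an effect already at smaller amounts:
compound 1 `CCOC(=O)CCCCCOc1cccc(CN(C(=O)c2ccc(-c3ccc(C(C)=O)s3)cc2)C(C)C)c1` gives > 26000 nM, a limit of the assay.
compound 2 `CCOC(=O)CCCCCOc1cccc(CN(C(=O)c2ccc(-c3cccc(OCc4ccccc4)c3)cc2)C(C)C)c1` gives > 26000 nM, a limit of the assay.
compound 3 `CCOC(=O)CCCCCOc1cccc(CN(C(=O)c2ccc(-c3cccc(OCC)c3)cc2)C(C)C)c1` gives > 22300 nM, a limit of the assay.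

Compound 3 therefore stands nowhere in particular on the numbers shown: its own value is a limit, and the two further values in this assay are limits as well, one sitting at the limit of > 22300 nM in this assay, at which 1 of the 3 values shown sits, and two at the limit of > 26000 nM in this assay, at which 2 of the 3 values shown sit. The two measured steps that lead into compound 3, a step that the two limits leave unreadable from compound 1 to compound 3 and a step that the two limits leave unreadable from compound 2 to compound 3, are accordingly unreadable in size and direction; the three values only say that none of the three compounds showed an effect within the tested range.

Compound 4 `CCOC(=O)CCCCCOc1cccc(CN(C(=O)c2ccc(-c3cccc(CC(=O)O)c3)cc2)C(C)C)c1` is the next compound, differing from compound 3 by carboxymethyl in place of ethoxy on an aromatic carbon. Going by the values given here, no measured step bears readably on this change, since every value is a limit. With nothing to read, no step beyond the scatter in this assay is expected in either direction, and the step that the limit leaves unreadable from compound 3 to compound 4 is the one that this expectation means. Compound 4 is estimated at 30000 nM, with a range from 15000 nM to 60000 nM, and most likely the assay again reports only a limit.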

Compound 4, half-maximal effective concentration: > 26000 nM
Compound 4: no number, only a limit; the forecaster's own chance of this, stated with the estimate: 85%; the middle value lies beyond the limit too.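

Going by these compounds alone, compound 4, like compound 1, compound 2 and compound 3, gives only a limit in this assay, so no step from any of them to compound 4 can be read. The compounds shown leave open at what concentration any of the four would show an effect, and whether their differing groups change that concentration at all.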